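Crown ether esters: from compound 2 to compound 3

The source may report more compounds than this note shows. Statements on the series, on what has been measured and on what is new or still open speak of the compounds shown alone.

Two esters of a shared crown ether core have been measured so far. Compound 1 `O=C(OCC1COCCOCCOCCOCCOCCO1)c1cccc(-c2ccc(Br)cc2)c1` gives 6200 nM in a functional assay on WiDr cells (Homo sapiens) for inhibition, read by sulforhodamine B assay, with a stated time of 48 h; a higher number here means a weaker inhibitor of growth, a lower number a stronger inhibitor of growth. Compound 2 `CC(C)=CC1C(C(=O)OCC2COCCOCCOCCOCCOCCO2)C1(C)C` stands at the highest of the two numbers, with a value in this assay of 56000 nM; its gap to compound 1 lies beyond the scatter. Compound 3 `CC/C=C/CC(=O)OCC1COCCOCCOCCOCCOCCO1` is not yet measured and differs from compound 2 in one place: pent-2-en-1-yl in place of 2,2-dimethyl-3-(2-methylprop-1-en-1-yl)cyclopropyl on a carbonyl carbon. For the measured compounds named here, no measured pair shows this change, so its size is unknown from the data. Going by the values given here, the step expected here is a 1.3-fold higher number from compound 2 to compound 3 (0.10 log units; within the scatter), judged small and most likely none beyond the scatter, with a higher number somewhat more probable than a lower one, since the shared core carries the only two values known. For compound 3 the estimate in this assay is 70000 nM, within a range from 25000 nM to 200000 nM.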

Compound 3, concentration for 50% growth inhibition: > 100000 nM
Compound 3 gave a limit, no number; the forecaster's own chance of this, stated with the estimate: 25%; middle value at least 1.4-fold (0.15 log units) from the limit.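

In this assay compound 3 gives > 100000 nM, which is a limit of the assay and not a number. For the compounds shown here, on a carbonyl carbon, pent-2-en-1-yl in place of 2,2-dimethyl-3-(2-methylprop-1-en-1-yl)cyclopropyl gives an at least 1.7-fold higher number from compound 2 to compound 3 (0.25 log units; that floor lies within the scatter), the first step that can be read at this position, so the direction is upward but the floor alone does not separate the change from the scatter. How far the true step lies beyond that floor stays unknown, and the reading is bounded only by the limit: the limit of > 100000 nM in this assay, at which 1 of the 3 values shown sits.

The change removes the three-membered ring and alters the chain together, and no compound shown separates these two parts. Also open, going by these compounds, is how a longer chain in place of pent-2-en-1-yl, or an amine carried on that chain, would read in this assay.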